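Methoxy for methyl on the chlorinated sulfonamide core

A few compounds are considered here, and "the series" means these few. Any claim that something is new, unique, unknown or untested is made for them only; others in the source may bear on it.

Compound 1 `Cc1ccc(-n2cc(NC(=O)c3cccc(NS(=O)(=O)c4ccccc4)c3)cn2)cc1` gives 6050 nM in a functional assay on HepG2 cells (Homo sapiens) for inhibition, read by MTT assay, with a stated time of 48 h; a lower number here means a stronger inhibitor, a higher number a weaker inhibitor. Compound 2 `COc1ccc(-n2cc(NC(=O)c3cccc(NS(=O)(=O)c4ccccc4)c3)cn2)cc1` gives 35700 nM in this assay; the change methoxy in place of methyl on an aromatic carbon makes a step of a 5.9-fold higher number from compound 1 to compound 2 (0.77 log units; beyond the scatter). Compound 3 `Cc1ccc(-n2cc(NC(=O)c3cccc(NS(=O)(=O)c4ccc(Cl)cc4)c3)cn2)cc1` gives 2440 nM in this assay, a step of a 2.5-fold lower number from compound 1 to compound 3 (0.39 log units; beyond the scatter), and it stands lowest of the three measured numbers.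

Compound 4 `COc1ccc(-n2cc(NC(=O)c3cccc(NS(=O)(=O)c4ccc(Cl)cc4)c3)cn2)cc1` is not yet measured. It differs from compound 3 by methoxy in place of methyl on an aromatic carbon, the same change already seen between compound 1 and compound 2; the two cores differ by chloro in place of hydrogen on an aromatic carbon, and the place of the change is the same in both pairs. Among the compounds with values here, the step from compound 3 to compound 4 in this assay is expected to be a 5.3-fold higher number from compound 3 to compound 4 (0.73 log units; beyond the scatter), close to the earlier one, resting on a single measured pair because a 5.9-fold higher number from compound 1 to compound 2 (0.77 log units; beyond the scatter) is the only instance of this change. Compound 4 is therefore estimated at 13000 nM, between 5000 nM and 35000 nM.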

Compound 4, half-maximal inhibitory concentration: 15200 nM
Estimate against measurement, compound 4: 1.2-fold (0.07 log units) below; measured number inside the range.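

In this assay, the change from 4-methylphenyl to 4-methoxyphenyl carries over to the chlorinated core, with a 6.2-fold higher number from compound 3 to compound 4 (0.79 log units; beyond the scatter), and matches the step on the core of compound 1: the same change on two cores in this assay, a 5.9-fold higher number (0.77 log units; beyond the scatter) from compound 1 to compound 2 and a 6.2-fold higher number (0.79 log units; beyond the scatter) from compound 3 to compound 4, 1.1-fold (0.02 log units) apart, within the scatter of two such steps. The chloro change likewise holds on the methoxy side, with a 2.3-fold lower number from compound 2 to compound 4 (0.37 log units; beyond the scatter), and matches its earlier step: the same change on two cores in this assay, a 2.5-fold lower number (0.39 log units; beyond the scatter) from compound 1 to compound 3 and a 2.3-fold lower number (0.37 log units; beyond the scatter) from compound 2 to compound 4, 1.1-fold (0.02 log units) apart, within the scatter of two such steps. These four compounds show the two changes acting independently on this pair of cores only; they do not show that this holds on other cores or why the numbers move.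

Open, going by these compounds, is whether ethoxy, an amine or a carboxylic acid in place of methoxy continues the trend. Also open, on these data alone, is whether bromo or nitrile in place of chloro gives a similar step.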